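The compounds below may be only part of what the source reports. "The series", "measured", "known", "first", "only" and "open" are said of these compounds alone.

Measured compounds:
compound 1 `N=C(N)N/N=C/c1c(-c2cccs2)nc2sccn12` gives 24000 nM in a functional assay on cells (Cancer cell lines, Homo sapiens) for inhibition; on this read-out higher numbers stand for weaker inhibition of growth and lower numbers for stronger inhibition of growth
compound 2 `Cc1cn2c(/C=N/NC(=N)N)c(-c3cccs3)nc2s1` gives 8130 nM in this assay
compound 3 `N=C(N)N/N=C/c1c(-c2cc(Cl)sc2Cl)nc2n1CCS2` gives 16200 nM in this assay

Among these three, compound 1 has the highest number in this assay. Compound 3 is the nearest, a step that lies within the scatter, so no order between compound 1 and compound 3 can be claimed. Going by the values given here, compound 2 is the furthest, and the only single-point step among the measured compounds is that one: a 3.0-fold lower number from compound 1 to compound 2 (0.47 log units; beyond the scatter). Compound 4 `Cc1cc(-c2nc3sccn3c2/C=N/NC(=N)N)c(C)s1` has not yet been measured. It differs from compound 1 in this way: 2,5-dimethylthiophen-3-yl in place of thiophen-2-yl on an aromatic carbon. The measured step from compound 1 to compound 2 bears only loosely on this change, since it adds a methyl to the shared core rather than altering the thiophen-2-yl, and compound 3 carries a different core, so its number shows only the general range. An improvement of modest size is therefore expected rather than a large one; the step in this assay from compound 1 to compound 4 is estimated as a 2.0-fold lower number from compound 1 to compound 4 (0.30 log units; within the scatter). For compound 4 the expected value is 12000 nM, in the range 4000 nM to 36000 nM.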

Compound 4, concentration for total growth inhibition: 32400 nM
For compound 4 the middle estimate is 2.7-fold (0.43 log units) below the measured one; the measured number falls inside the stated range.
By their numbers in this assay, from the lowest: compounds 2, 3, 1 and 4 (each within the scatter of the next, the first and the last beyond it).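

In this assay, putting 2,5-dimethylthiophen-3-yl in place of thiophen-2-yl on this aromatic carbon gives a 1.4-fold higher number from compound 1 to compound 4 (0.13 log units; within the scatter), so this first exchange at the position produces no readable change. The larger group, with its two methyl groups, therefore leaves the number where compound 1 has it, whereas the methyl placed elsewhere on the shared core gave a 3.0-fold lower number from compound 1 to compound 2 (0.47 log units; beyond the scatter), a step beyond the scatter. Nothing available accounts for this result.

A plain thiophen-3-yl would be needed to separate the shift in the thiophene's point of attachment from the two methyl groups, since the exchange alters both at once. As far as these compounds go, whether a phenyl ring or a pyridine ring on this carbon would move the number beyond the scatter remains open.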